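Chalcone series: removing one methoxy from compound 2

This account rests on a few compounds, and the source may have more. Where it says the series, first, only, none or still open, it means among the compounds named here.

In a functional assay on HCT-116 cells (Homo sapiens) for inhibition, read by sulforhodamine B assay, with a stated time of 72 h (on this read-out lower numbers stand for stronger inhibition and higher numbers for weaker inhibition), compound 1 `COc1ccc(C(=O)/C=C/c2cn(-c3ccccc3)nc2-c2cccnc2)c(OC)c1` gives 1300 nM and compound 2 `COc1ccc(C(=O)/C=C/c2cn(-c3ccccc3)nc2-c2ccncc2)c(OC)c1OC` gives 1300 nM; the two values are level at the digits shown, within the scatter. Compound 3 `COc1ccc(C(=O)/C=C/c2cn(-c3ccccc3)nc2-c2ccncc2)c(OC)c1` is compound 2 with hydrogen in place of methoxy on an aromatic carbon, a hydrogen in place of methoxy on an aromatic carbon. Among the measured compounds shown here, no measured step of this kind exists, and the pair compound 1 and compound 2 shows no change. The step from compound 2 to compound 3 is therefore expected to be small, no change at the digits printed from compound 2 to compound 3 (within the scatter), with no direction beyond the scatter. Compound 3 is estimated at 1300 nM, within 450 nM to 3800 nM.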

Compound 3, half-maximal inhibitory concentration: 4400 nM
Beside the measured number, compound 3's estimate is 3.4-fold (0.53 log units) below it; measured number above the stated range.
By their numbers in this assay, from the lowest: compounds 1 and 2 (each within the scatter of the next); then compound 3.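

At this position, ortho to two methoxy groups and meta to a large group, the methoxy counts: hydrogen in its place gives a 3.4-fold higher number from compound 2 to compound 3 (0.53 log units; beyond the scatter) in this assay, a modest loss of inhibition. The pyridine attachment also counts, as pyridin-4-yl in place of pyridin-3-yl gives a 3.4-fold higher number from compound 1 to compound 3 (0.53 log units; beyond the scatter) with the same methoxy pattern. No evidence on hand bears on either step.

Open, from the compounds shown here alone, is whether a hydroxyl, ethoxy or an amine at this position would keep the level of compound 2. Also open, going by these compounds, is whether the pyridine step keeps its size when this methoxy is present.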